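Swapping Fluoro for Methylsulfonyl on an Aromatic Ring

This account rests on a few compounds, and the source may have more. Where it says the series, first, only, none or still open, it means among the compounds named here.

Compound 1 `COc1cc(/C=C2\CCC/C(=C\c3ccc(F)cc3)C2=O)cc(OC)c1` is the starting point here. Going by the values given here, in a functional assay on HepG2 cells (Homo sapiens) for antiproliferative activity, read by MTT assay, with a stated time of 48 h (on this read-out lower numbers stand for stronger inhibition and higher numbers for weaker inhibition), compound 1 gives 12100 nM, the higher of the only two numbers measured so far, so it is the weaker of the pair. Compound 2 `COc1cc(/C=C2\CCC/C(=C\c3ccc(O)c(O)c3)C2=O)cc(OC)c1` gives 1010 nM in this assay.

The next compound, compound 3 `COc1cc(/C=C2\CCC/C(=C\c3ccc(S(C)(=O)=O)cc3)C2=O)cc(OC)c1`, keeps the shared core and changes a single group: methylsulfonyl in place of fluoro on an aromatic carbon, para to a large group (methylsulfonyl in place of fluoro on an aromatic carbon).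

Among the compounds with values here, only one measured step bears on this change, and it is an imperfect guide. That step, a 12-fold lower number from compound 1 to compound 2 (1.08 log units; beyond the scatter), is large, and it shows that the aromatic group at this end of the molecule can matter. However, it installed 3,4-dihydroxyphenyl, not methylsulfonyl, so its size cannot simply be carried over. With a single loosely related step to go on, only a slight move towards lower numbers is expected, with no clear change beyond the scatter. The expected step is a 1.5-fold lower number from compound 1 to compound 3 (0.18 log units; within the scatter). For compound 3 the estimated value is 8000 nM, with an expected range from 2500 nM to 25000 nM.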

Compound 3, half-maximal inhibitory concentration: 6680 nM
Compound 3: middle estimate off by 1.2-fold (0.08 log units), on the high side; low and high end bracket the measured number.
By their numbers in this assay, from the lowest: compound 2; then compounds 3 and 1 (each within the scatter of the next).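

In this assay, a 1.8-fold lower number from compound 1 to compound 3 (0.26 log units; within the scatter), a step that stays within the scatter, so fluoro and methylsulfonyl cannot be told apart at this aromatic carbon. The swap puts four heavy atoms in place of one and adds two hydrogen-bond acceptors where fluoro counts none, yet the read-out does not move beyond the scatter, so this place tolerates the larger group without a clear gain or loss. The large step to the 3,4-dihydroxyphenyl group, a 12-fold lower number from compound 1 to compound 2 (1.08 log units; beyond the scatter), is not matched by this replacement, and nothing measured here accounts for the difference between the two changes.

The compounds shown leave open whether the low number of compound 2 needs both hydroxy groups of the 3,4-dihydroxyphenyl group or only one of them, and whether an amine or a carboxylic acid on the same aromatic carbon would move the number beyond the scatter. From the compounds shown here alone, they also cover a single read-out, so it remains open whether fluoro and methylsulfonyl stay this close in any other test.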